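Swapping a Sulfone for a Thioether on a Shared Core

This account rests on a few compounds, and the source may have more. Where it says the series, first, only, none or still open, it means among the compounds named here.

Compound 1 `CS(=O)(=O)c1ccc(F)cc1NCC1=NCCN1` and compound 2 `CS(=O)(=O)c1cc(F)ccc1NCC1=NCCN1` are built from the same atoms joined differently; the difference between the two cores is not broken down here. In an assay for binding affinity to Alpha-1A adrenergic receptor (Homo sapiens), read by radioligand binding (a lower number here means a stronger inhibitor, a higher number a weaker inhibitor), compound 1 gives 813 nM, and compound 2 gives 661 nM, two numbers within the usual scatter of each other. Compound 3 `CSc1ccc(F)cc1NCC1=NCCN1` differs from compound 1 by methylsulfanyl in place of methylsulfonyl on an aromatic carbon, and in this assay compound 3 gives 33.1 nM, a step of a 25-fold lower number from compound 1 to compound 3 (1.39 log units; beyond the scatter). Compound 4 `CSc1cc(F)ccc1NCC1=NCCN1` has not been measured; it differs from compound 2 by methylsulfanyl in place of methylsulfonyl on an aromatic carbon. This is the same kind of change, not the same, since the place is para to the fluoro group in compound 3 but meta to it in compound 4. For compound 4 a step of a 22-fold lower number from compound 2 to compound 4 (1.34 log units; beyond the scatter) is expected, resting on a 25-fold lower number from compound 1 to compound 3 (1.39 log units; beyond the scatter). Compound 4 is therefore estimated at 30 nM, likely between 10 nM and 90 nM.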

Compound 4, inhibition constant: 20.9 nM
Estimate against measurement, compound 4: 1.4-fold (0.16 log units) above; the range from low to high includes it.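

In this assay the change from methylsulfonyl to methylsulfanyl brings a 32-fold lower number from compound 2 to compound 4 (1.50 log units; beyond the scatter) and matches the earlier step on the other core: the same change on two cores in this assay, a 25-fold lower number (1.39 log units; beyond the scatter) from compound 1 to compound 3 and a 32-fold lower number (1.50 log units; beyond the scatter) from compound 2 to compound 4, 1.3-fold (0.11 log units) apart, within the scatter of two such steps. Across these two cores, then, the swap carries over as a large step of similar size, and the earlier step was a fair guide to the later one. For the compounds shown here, this rests on only two pairs of compounds, so it does not show that the step would hold on a third core, and it does not explain why the number falls.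

The compounds shown leave open what other groups in the same place would do, such as an amine or a longer chain like ethylsulfanyl. Also open, as far as these compounds go, is what hydrogen in place of the fluoro group would do.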